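This account rests on a few compounds, and the source may have more. Where it says the series, first, only, none or still open, it means among the compounds named here.

Measured so far:
Compound 1 `Cc1noc(C)c1-c1ccc2c(c1)C(c1ccccc1)N(Cc1nnc(-c3ccccc3)o1)C(=O)N2C`: 26.7%
Compound 2 `Cc1noc(C)c1-c1ccc2c(c1)C(c1ccccc1)N(Cc1nc(-c3ccccc3)cs1)C(=O)N2C`: 12.7%

Both compounds were tested in a functional assay on U-266 cells (Homo sapiens) for inhibition, read by MTT assay, with a stated time of 48 h, tested at 0.1 uM (a lower number here means less inhibition, a higher number more inhibition at the concentration tested (going by the name of the read-out)), where compound 2 gives the lower of the two numbers and compound 1 the higher. For the measured compounds named here, the only measured step is a number 14 percentage points lower from compound 1 to compound 2 (beyond the scatter), and it concerns the five-membered heterocycle on the chain carbon bound to the ring nitrogen.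

Compound 3 `Cc1noc(C)c1-c1ccc2c(c1)C(c1ccccc1)N(Cc1nc(-c3ccc(F)cc3)cs1)C(=O)N2C` has not yet been measured. Compared with compound 2, it carries fluoro in place of hydrogen on an aromatic carbon. Going by the values given here, this change sits on the phenyl ring attached to the thiazole, not on the heterocycle that the measured step exchanged, so no measured step speaks directly to it. With nothing to point either way, the expected step of a number 2.3 percentage points higher from compound 2 to compound 3 (within the scatter) is one that stays within the usual scatter. Compound 3 is therefore estimated at 15%, with a range from 0% to 35%.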

Compound 3, a percentage reported as inhibition, at one concentration (the size of the read-out at that concentration, not a potency): 12.6%
Estimate against measurement, compound 3: 2.4 percentage points above; low and high end bracket the measured number.
By their numbers in this assay, from the lowest: compounds 3 and 2 (each within the scatter of the next); then compound 1.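

In this assay, placing fluoro on the phenyl ring carried by the thiazole, para to a large group, gives a number 0.1 percentage points lower from compound 2 to compound 3 (within the scatter) and so leaves no readable mark at this position. The gap to the oxadiazole compound stays in place, with a number 14.1 percentage points lower from compound 1 to compound 3 (beyond the scatter) and thus a size much like that of the earlier exchange of the heterocycle, so among these three compounds only the heterocycle exchange moves the number beyond the scatter. Nothing available here explains why either change has the outcome it does.

Going by these compounds, it remains open whether a different group at this position, such as methoxy, an amine or a carboxylic acid, would shift the number. On these data alone, it is equally open whether fluoro would behave the same way on the phenyl ring of compound 1 or at other concentrations.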